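Series notes: cytotoxicity limits and an unmeasured hydroxy analogue

The compounds below may be only part of what the source reports. "The series", "measured", "known", "first", "only" and "open" are said of these compounds alone.

Measured so far:
- Compound 1, `CCOC(=O)c1c(-c2cccc(OC(C)C)c2)[nH]c2cc(OC)ccc2c1=O`, in an ADME assay on BJ cells (Homo sapiens) for cytotoxicity, read by luminescence, with a stated time of 72 h (a lower number here means that less compound is needed, a higher number that more compound is needed for the effect), gives > 21500 nM, which is a limit of the assay.
- Compound 2, `CCOC(=O)c1c(-c2cccc(O)c2)[nH]c2cc(OC)ccc2c1=O`, in this assay gives > 21500 nM, again a limit.
- Compound 3, `CCOC(=O)c1c(-c2cccc(-c3ccccc3)c2)[nH]c2cc(OC(C)C)ccc2c1=O`, in this assay gives > 21500 nM, also a limit.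

The change hydrogen in place of isopropyl on an oxygen on an aromatic ring gives the step that the two limits leave unreadable from compound 1 to compound 2. All three values sit at the limit of > 21500 nM in this assay, at which 3 of the 3 values shown sit, so the shown data hold no readable step at all. How the core of compound 3 differs from the core of compound 1 is not broken down here.

Compound 4, `CCOC(=O)c1c(-c2cccc(-c3ccccc3)c2)[nH]c2cc(O)ccc2c1=O`, is not yet measured; it arises from compound 3 by hydrogen in place of isopropyl on an oxygen on an aromatic ring, the same change as from compound 1 to compound 2, at a place described in the same words.

For compound 4 the expected step in this assay is a step that the limit leaves unreadable from compound 3 to compound 4, resting on the fact that compound 1 and compound 2 both sit at the limit of > 21500 nM in this assay, at which 3 of the 3 values shown sit. Compound 4 is estimated at 30000 nM, between 12000 nM and 100000 nM, most likely reported only as a limit.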

Compound 4, half-maximal effective concentration: > 21500 nM
Compound 4 ended at the assay's limit; the forecaster's own chance of this, stated with the estimate: 85%; the middle value is on the limit's open side.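

Compound 3 and compound 4 both sit at a limit in this assay, so the change from isopropoxy to hydroxy gives no readable step between them: the limit of > 21500 nM in this assay, at which 4 of the 4 values shown sit.

The compounds shown leave open whether this change alters the half-maximal effective concentration in this assay at all, and what structure would give a value that is not a limit.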